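Bromo for phenyl on the aryl of compound 1

The source may hold more compounds than are shown below. What is called first, only, known or untested is meant among the compounds shown, and "the series" means these compounds.

Compound 1 `O=C1Nc2ccc(Br)cc2/C1=N/NC(=S)N/N=C/c1ccc(-c2ccccc2)cc1`: 3250 nM
Compound 2 `COc1ccc(/C=N/NC(=S)N/N=C2\C(=O)Nc3ccc(C)cc32)cc1O`: 2730 nM
Compound 3 `Cc1ccc2c(c1)/C(=N/NC(=S)N/N=C/c1ccccc1Br)C(=O)N2`: > 50000 nM

In a functional assay on HeLa cells (Homo sapiens) for inhibition, read by MTT assay (a higher number here means a weaker inhibitor, a lower number a stronger inhibitor), compound 1 gives 3250 nM and compound 2 gives 2730 nM; the two sit within the scatter of each other, so no order between them is claimed. For compound 3 this assay reports only a limit, > 50000 nM. For the measured compounds named here, the single measured step, an at least 18-fold higher number from compound 2 to compound 3 (1.26 log units; beyond the scatter), is a large loss, and it rests on the limit (the limit of > 50000 nM in this assay, at which 1 of the 3 values shown sits).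

Compound 4 `O=C1Nc2ccc(Br)cc2/C1=N/NC(=S)N/N=C/c1ccc(Br)cc1` differs from compound 1 by bromo in place of phenyl on an aromatic carbon. Going by the values given here, no measured step swaps exactly these two groups. The step from compound 2 to compound 3 also exchanges one aryl for another on a carbon with a double bond to nitrogen, so it bears only loosely on the change here: it shows that a bromophenyl at that place can sit at the limit, but that swap removed the hydroxy and methoxy groups and involved 2-bromophenyl rather than a bromo para to a large group. Compound 4 is therefore expected to weaken moderately, a 2.2-fold higher number from compound 1 to compound 4 (0.33 log units; beyond the scatter), with wide uncertainty. Compound 4 is estimated at 7000 nM, between 2000 nM and 30000 nM.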

Compound 4, half-maximal inhibitory concentration: 4680 nM
Beside the measured number, compound 4's estimate is 1.5-fold (0.17 log units) above it; the range from low to high includes it.
By their numbers in this assay, from the lowest: compounds 2, 1 and 4 (each within the scatter of the next). At a limit, above all of these: compound 3.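

In this assay, the exchange of phenyl for bromo on an aromatic carbon, para to a large group, gives a 1.4-fold higher number from compound 1 to compound 4 (0.16 log units; within the scatter). At this position, a six-membered aromatic ring of carbon only and a single bromine therefore give numbers that cannot be told apart, so the outer phenyl of compound 1 is not required for a value in this range. No measurement shown gives a cause for this step.

On these data alone, an amine, a carboxylic acid or a longer chain on the same aromatic carbon remains open, as does whether such groups would stay within the scatter of compound 1. As far as these compounds go, it is also open whether the same exchange would read alike on the core of compound 2, which carries methyl where compound 1 carries bromo.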